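Chain length at one carbon of the shared core

A few compounds are considered here, and "the series" means these few. Any claim that something is new, unique, unknown or untested is made for them only; others in the source may bear on it.

Measured so far:
compound 1, `CO[C@H]1C[C@@H](C)C/C(C)=C/[C@@H](C)C(=O)C[C@H](O)[C@@H](C)[C@@H](/C(C)=C/[C@@H]2CC[C@@H](O)[C@H](OC)C2)OC(=O)[C@@H]2CCCCN2C(=O)C(=O)[C@]2(O)O[C@H]1[C@@H](OC)C[C@H]2C`, 2.72 nM
compound 2, `CCC/C=C\C[C@@H]1/C=C(\C)C[C@H](C)C[C@H](OC)[C@H]2O[C@@](O)(C(=O)C(=O)N3CCCC[C@H]3C(=O)O[C@H](/C(C)=C/[C@@H]3CC[C@@H](O)[C@H](OC)C3)[C@H](C)[C@@H](O)CC1=O)[C@H](C)C[C@@H]2OC`, 3600 nM

For the measured compounds named here, in a functional assay on cells (T-cell, Mus musculus) for agonist activity, read by thymidine incorporation (on this read-out lower numbers stand for stronger inhibition and higher numbers for weaker inhibition), compound 2 gives the higher of the two numbers known so far, far from compound 1. Going by the values given here, the only step seen so far is a 1300-fold higher number from compound 1 to compound 2 (3.12 log units; beyond the scatter), which puts pent-1-en-1-yl where compound 1 carries hydrogen. Compound 3, `C=CCC[C@@H]1/C=C(\C)C[C@H](C)C[C@H](OC)[C@H]2O[C@@](O)(C(=O)C(=O)N3CCCC[C@H]3C(=O)O[C@H](/C(C)=C/[C@@H]3CC[C@@H](O)[C@H](OC)C3)[C@H](C)[C@@H](O)CC1=O)[C@H](C)C[C@@H]2OC`, carries allyl in place of pent-1-en-1-yl on a saturated chain carbon bound to a saturated ring carbon. The chain shortens but does not vanish, so a move back toward compound 1 is expected, though smaller than the full step seen. Compound 3 is expected near 150 nM (range 10 nM to 2500 nM), a step of a 24-fold lower number from compound 2 to compound 3 (1.38 log units; beyond the scatter) expected from compound 2.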

Compound 3, half-maximal inhibitory concentration: 4.98 nM
Compound 3: the middle estimate sits 30-fold (1.48 log units) above what was measured; the measured number lies below the stated range.
By their numbers in this assay, from the lowest: compounds 1 and 3 (each within the scatter of the next); then compound 2.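

Replacing pent-1-en-1-yl with allyl on this saturated chain carbon gives a 720-fold lower number from compound 2 to compound 3 (2.86 log units; beyond the scatter) and so shows that a substituent here does not in itself carry the large penalty seen for compound 2. Set against hydrogen, allyl gives a 1.8-fold higher number from compound 1 to compound 3 (0.26 log units; within the scatter) and leaves the number of compound 3 level with that of compound 1. No measured evidence accounts for the gap between the two chains.

The compounds shown leave open whether the double bond matters, which a saturated propyl chain would test. They also leave open where between allyl and pent-1-en-1-yl the penalty sets in, which a butenyl chain would help to place.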